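This account rests on a few compounds, and the source may have more. Where it says the series, first, only, none or still open, it means among the compounds named here.

This series shares a single saturated core and varies only the group attached to it. Compound 1 `CC(=O)NC12CCCC3CC(CCC31)C2` carries an acetamido group, and in an ADME assay (Gallus gallus) for cytotoxicity, read by microscopy, with a stated time of 24 h (on this read-out higher numbers stand for lower toxicity in this test and lower numbers for higher toxicity in this test), compound 1 gives 3000000 nM. Compound 2 `COC(=O)C12CCCC3CC(CCC31)C2` carries a methoxycarbonyl group instead, and in this assay compound 2 gives 80000 nM. The change between them produced a 38-fold lower number from compound 1 to compound 2 (1.57 log units; beyond the scatter). On these data alone, compound 3 `O=C(Cl)C12CCCC3CC(CCC31)C2` carries an acyl chloride, and in this assay compound 3 gives no result reported, so its standing in this test is unknown. Compound 4 `NC(=O)C12CCCC3CC(CCC31)C2` differs from compound 3 as follows: amino in place of chloro on a carbonyl carbon. Among the measured compounds shown here, no measured step exchanges a chloro for an amino on a carbonyl carbon, so the step from compound 3 to compound 4 in this assay cannot be read from the measured pairs; the only guidance is that the two measured values lie far apart and both carry a carbonyl-bearing group on the same ring carbon. For compound 4 the value in this assay is therefore estimated, with wide uncertainty, at 1000000 nM, in a range from 100000 nM to 3000000 nM.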

Compound 4, minimum cytotoxic concentration: 5200000 nM
Compound 4: middle estimate off by 5.2-fold (0.72 log units), on the low side; the whole stated range lies below it.
By their numbers in this assay, from the lowest: compound 2; then compounds 1 and 4 (each within the scatter of the next).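

In this assay, keeping a carbonyl on the saturated ring carbon does not by itself give a low number: amino in place of methoxy on that carbonyl carbon produces a 65-fold higher number from compound 2 to compound 4 (1.81 log units; beyond the scatter). Carbamoyl in place of acetamido gives a 1.7-fold higher number from compound 1 to compound 4 (0.24 log units; within the scatter), so this test does not separate these two groups, and among the three measured compounds only compound 2 stands apart. No available data explain either result.

Among the compounds shown here, compound 3 has no reported result, so no step involving it can be read. On these data alone, whether the low number is particular to the methoxycarbonyl group remains open, since a carboxylic acid, an ethyl ester or an N-methyl amide on the same ring carbon could either share it or resemble compound 4.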